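Methoxy on the benzoyl ring of a bromo-indole analogue

A few compounds are considered here, and "the series" means these few. Any claim that something is new, unique, unknown or untested is made for them only; others in the source may bear on it.

The measured compounds are:
compound 1, `COc1ccc(C(=O)n2c(-c3cn(C)c4ccccc34)nc3ccccc32)cc1OC` — 10200 nM
compound 2, `COc1ccc2c(c1)c(-c1nc3ccccc3n1C(=O)c1ccc(OC)c(OC)c1)cn2C` — 6300 nM
compound 3, `Cn1cc(-c2nc3ccccc3n2C(=O)c2ccccc2)c2cc(Br)ccc21` — 50300 nM

All three were tested in a functional assay on MCF7 cells (Homo sapiens) for inhibition, read by MTT assay, with a stated time of 24 h; a lower number here means a stronger inhibitor of growth, a higher number a weaker inhibitor of growth. Compound 2 differs from compound 1 by methoxy in place of hydrogen on an aromatic carbon, and that change gave a 1.6-fold lower number from compound 1 to compound 2 (0.21 log units; within the scatter). Compound 3 gives the highest of the three numbers; how its core differs from that of compound 1 is not broken down here.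

Compound 4, `COc1ccccc1C(=O)n1c(-c2cn(C)c3ccc(Br)cc23)nc2ccccc21`, has not yet been measured. It differs from compound 3 by methoxy in place of hydrogen on an aromatic carbon. This is the same kind of change as from compound 1 to compound 2, but not the same: there the methoxy entered on a ring that is part of a fused system of two rings, meta and para to a fused ring, whereas here it enters on a six-membered ring of carbon only, ortho to a large group. Within the data shown here, the one measured example of this change stayed within the scatter, so compound 4 is expected to stay close to compound 3, with an estimated step of a 1.3-fold lower number from compound 3 to compound 4 (0.10 log units; within the scatter). Compound 4 is therefore estimated at 40000 nM, between 15000 nM and 100000 nM.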

Compound 4, concentration for 50% growth inhibition: 36200 nM
The estimate for compound 4 lay 1.1-fold (0.04 log units) above the measured number, and the stated range covers the measured number.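

In this assay, the change from phenyl to 2-methoxyphenyl came to a 1.4-fold lower number from compound 3 to compound 4 (0.14 log units; within the scatter). Set beside the earlier step on the other core, the new step agrees with it: the same change on two cores in this assay, a 1.6-fold lower number (0.21 log units; within the scatter) from compound 1 to compound 2 and a 1.4-fold lower number (0.14 log units; within the scatter) from compound 3 to compound 4, 1.2-fold (0.07 log units) apart, within the scatter of two such steps

On these two cores, then, methoxy in place of hydrogen on an aromatic carbon stayed within the scatter both times, so the result carried from one core to the other, even though the methoxy entered on a different ring in each case. This does not show that the change has a real effect of any set size, since neither step can be told from scatter, and two pairs say nothing about cores beyond those shown.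

The compounds shown leave open whether a group other than methoxy on the benzoyl ring, such as an amine, a carboxylic acid or a longer chain, would give a step beyond the scatter. They also leave open whether methoxy placed elsewhere on that ring would give a step of similar size.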